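The source may report more compounds than this note shows. Statements on the series, on what has been measured and on what is new or still open speak of the compounds shown alone.

Series values in an ADME assay on CEMx174 cells (Homo sapiens) for cytotoxicity; on this read-out lower numbers stand for higher toxicity in this test and higher numbers for lower toxicity in this test:
- Compound 1 `CCC1=C(C(=O)OCC2CCCCC2)C(c2cccc(N)c2)NC(=O)N1`: > 10000 nM, a limit.
- Compound 2 `CCC1=C(C(=O)OCC2CCCCC2)C(c2ccc(NC)cc2)NC(=O)N1`: > 10000 nM, a limit.
- Compound 3 `CCC1=C(C(=O)OCC2CCCCC2)C(c2ccc(N(C)C)cc2)NC(=O)N1`: > 10000 nM, a limit.

Compound 3 has no number, only (the limit of > 10000 nM in this assay, at which 3 of the 3 values shown sit). The next change is cyano in place of dimethylamino on an aromatic carbon, and gives compound 4 `CCC1=C(C(=O)OCC2CCCCC2)C(c2ccc(C#N)cc2)NC(=O)N1`. For the measured compounds named here, three measured steps bear on it: a step that the two limits leave unreadable from compound 1 to compound 2, a step that the two limits leave unreadable from compound 1 to compound 3 and a step that the two limits leave unreadable from compound 2 to compound 3. None of them has a readable size, so they give no direction for this change. The closest guide is a step that the two limits leave unreadable from compound 2 to compound 3, a change at the same aromatic nitrogen substituent. With nothing measured against it, no shift beyond the scatter is expected in this assay, and the expected step is a step that the limit leaves unreadable from compound 3 to compound 4. For compound 4 the estimate is 15000 nM, with an expected range of 6000 nM to 40000 nM.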

Compound 4, half-maximal cytotoxic concentration: > 10000 nM
Compound 4 was reported as a limit; the forecaster's own chance of this, stated with the estimate: 80%; the middle value lies beyond the limit too.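

No step between compound 1, compound 2, compound 3 and compound 4 can be read in this assay, as all four values are limits: the limit of > 10000 nM in this assay, at which 4 of the 4 values shown sit.

The compounds shown leave open whether any of these changes shifts cytotoxicity at all.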